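Cinnamamide to cinnamate ester: a change without precedent

The source may report more compounds than this note shows. Statements on the series, on what has been measured and on what is new or still open speak of the compounds shown alone.

Compound 3 `CCCNC(=O)/C=C/c1ccccc1` stands lowest of the three measured compounds: in a functional assay on the whole organism for inhibition, with Brassica rapa subsp. chinensis as the target, with a stated time of 3 days, tested at 100 ppm (on this read-out lower numbers stand for less inhibition of growth and higher numbers for more inhibition of growth at the one concentration tested), compound 3 gives 15%, whereas compound 1 `CCCCCNC(=O)/C=C/c1ccccc1` gives 60% and compound 2 `CCCCCCCCNC(=O)/C=C/c1ccccc1` gives 34%. The measured steps are a number 45 percentage points lower from compound 1 to compound 3 (beyond the scatter), a number 19 percentage points lower from compound 2 to compound 3 (beyond the scatter) and a number 26 percentage points lower from compound 1 to compound 2 (beyond the scatter), all of them changes in chain length alone. Compound 4 `CCCCOC(=O)/C=C/c1ccccc1` differs from compound 3 by butoxy in place of propylamino on a carbonyl carbon. Going by the values given here, no measured step bears directly on this exchange of the amide for an ester; the chain-length steps suggest only that lengthening the chain from propyl raised the number. Compound 4 is therefore expected to show a modest rise, a number 20 percentage points higher from compound 3 to compound 4 (beyond the scatter), with wide uncertainty, giving an estimated 35% in the range 10% to 65%.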

Compound 4, percent growth inhibition at one concentration: 5%
Compound 4: the middle estimate sits 30 percentage points above what was measured; the measured number lies below the stated range.
By their numbers in this assay, from the lowest: compounds 4 and 3 (each within the scatter of the next); then compound 2; then compound 1.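

In this assay, butoxy in place of propylamino on a carbonyl carbon gives a number 10 percentage points lower from compound 3 to compound 4 (within the scatter), so at this low end of the series the amide and the ester cannot be told apart. The exchange removes the amide hydrogen and changes the chain, yet neither alteration yields a separable difference here. No independent measurement speaks to why the two compounds read alike.

It remains open whether a pentyl ester would match the amide of compound 1, since only one ester chain is shown. A carboxylic acid or an N-methyl amide at this carbonyl carbon also remains untested in the compounds shown.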